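The source may report more compounds than this note shows. Statements on the series, on what has been measured and on what is new or still open speak of the compounds shown alone.

Of the compounds shown here, three have been measured in a functional assay on the whole organism (strain albino) for inhibition, with Rattus norvegicus as the target, read by paw edema, with stated times of 30 min and 4 h, at a dose of 100 mg/kg by the oral route; on this read-out higher numbers stand for more inhibition at the one dose given (going by the name of the read-out) and lower numbers for less inhibition: compound 1 `COc1ccc(/C=C/C(=O)c2ccc(NC(=O)CO[N+](=O)[O-])cc2)cc1` gives 51%; compound 2 `O=C(CO[N+](=O)[O-])Nc1ccc(C(=O)/C=C/c2ccco2)cc1` gives 40%; compound 3 `CC(Br)C(=O)Nc1ccc(C(=O)/C=C/c2ccco2)cc1` gives 36%.

Compound 2 stands second highest of the three numbers. In this assay the reading is a number 11 percentage points lower from compound 1 to compound 2 (beyond the scatter), beyond the scatter, whereas it is a number 4 percentage points lower from compound 2 to compound 3 (within the scatter), within the scatter.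

Compound 4 `CC(=O)c1ccc(OCC(=O)Nc2ccc(C(=O)/C=C/c3ccco3)cc2)cc1` differs from compound 2 in one place: 4-acetylphenyl in place of nitro on an oxygen on a saturated carbon. Going by the values given here, only the step from compound 2 to compound 3 bears on this, since it also exchanges the group on the carbonyl-bound side chain, and that step stayed within the scatter. The step from compound 1 to compound 2 changes the other end of the molecule and does not bear on it. No step beyond the scatter is therefore expected, so the estimated change is no change at the digits printed from compound 2 to compound 4 (within the scatter). Compound 4 is estimated to give 40%, with an expected range from 28% to 52%.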

Compound 4, a percentage reported as inhibition, in the whole organism at one dose (the size of the read-out at that dose, not a potency): 39%
Beside the measured number, compound 4's estimate is 1 percentage points above it, within the range that was stated.
By their numbers in this assay, from the lowest: compounds 3, 4 and 2 (each within the scatter of the next); then compound 1.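

In this assay the exchange of nitro for 4-acetylphenyl on an oxygen on a saturated carbon gives a number 1 percentage points lower from compound 2 to compound 4 (within the scatter) and so brings a six-membered aromatic ring and 9 heavy atoms to this place without a step beyond the scatter. The earlier compounds had shown no ring at this place, only the 1-bromoethyl exchange on the carbonyl carbon. No measurement offered here accounts for this result.

On these data alone, whether an amine or a carboxylic acid on this oxygen would read alike stays open. So does whether 4-acetylphenyl would behave the same with 4-methoxyphenyl in place of furan-2-yl.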